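A few compounds are considered here, and "the series" means these few. Any claim that something is new, unique, unknown or untested is made for them only; others in the source may bear on it.

Of the compounds shown here, three that share one core have been tested in an ADME assay on HEK293 cells (Homo sapiens) for cytotoxicity, read by MTT assay, with a stated time of 24 h; a lower number here means a stronger inhibitor, a higher number a weaker inhibitor. Compound 1 `CN(C)CCCNc1nc2cc([N+](=O)[O-])ccc2nc1NCc1ccc(C(F)(F)F)cc1` gives 5.66 ug/mL, compound 2 `Cc1ccc(CNc2nc3ccc([N+](=O)[O-])cc3nc2NCCCN(C)C)cc1` gives 15.8 ug/mL, and compound 3 `CN(C)CCCNc1nc2cc([N+](=O)[O-])ccc2nc1NCc1ccccc1C(F)(F)F` gives 24.7 ug/mL. Compound 3 stands level with compound 2, as a 1.6-fold higher number from compound 2 to compound 3 (0.19 log units; within the scatter) shows, and clearly apart from compound 1, with a 4.4-fold higher number from compound 1 to compound 3 (0.64 log units; beyond the scatter).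

Compound 4 `CN(C)CCCNc1nc2cc([N+](=O)[O-])ccc2nc1NCc1ccccc1Br` alters compound 3 in one place: bromo in place of trifluoromethyl on an aromatic carbon. This puts bromo in place of trifluoromethyl on an aromatic carbon, ortho to a large group. For the measured compounds named here, no tested pair makes this exact swap, so the evidence is indirect. The nearest case is a 2.8-fold higher number from compound 1 to compound 2 (0.45 log units; beyond the scatter), where methyl replaces trifluoromethyl on an aromatic carbon, though in the 4-(trifluoromethyl)phenyl series. Going by the values given here, that step was modest, and so was the one between compound 1 and compound 3. Neither points firmly in a direction for this swap, so no change beyond the scatter is expected, with an estimated 1.2-fold lower number from compound 3 to compound 4 (0.09 log units; within the scatter). Compound 4 is estimated at 20 ug/mL, with an expected range of 8 ug/mL to 45 ug/mL.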

Compound 4, half-maximal inhibitory concentration: 51.9 ug/mL
Compound 4: middle estimate off by 2.6-fold (0.41 log units), on the low side, and the stated range ends below it.
By their numbers in this assay, from the lowest: compound 1; then compounds 2 and 3 (each within the scatter of the next); then compound 4.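

In this assay, for the compounds shown here, the swap of trifluoromethyl, with 4 heavy atoms, for bromo, with 1, on an aromatic carbon ortho to a large group gives the first direct reading at this position: a 2.1-fold higher number from compound 3 to compound 4 (0.32 log units; beyond the scatter) lies just beyond the scatter, so this change is not neutral here. Compound 3 stood level with compound 2, yet a 3.3-fold higher number from compound 2 to compound 4 (0.52 log units; beyond the scatter) now separates the bromo compound from that neighbour too, and a 9.2-fold higher number from compound 1 to compound 4 (0.96 log units; beyond the scatter) makes compound 4 the weakest inhibitor of the four and stretches the span of the series. Nothing measured here explains the size or direction of this step.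

Going by these compounds, whether an amine or a carboxylic acid on the same aromatic carbon would raise or lower the number remains open. So does whether bromo in place of trifluoromethyl in compound 1 would give a similar step.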